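Benzyl variation on the shared core: a trifluorophenyl analogue

The source may report more compounds than this note shows. Statements on the series, on what has been measured and on what is new or still open speak of the compounds shown alone.

Measured so far in an assay on Sf21 cells for inhibition of high affinity nerve growth factor receptor (Homo sapiens), read by HTRF, with a stated time of 30 min, in the presence of a further agent that is not named here; on this read-out lower numbers stand for stronger inhibition and higher numbers for weaker inhibition:
compound 1 `CC1(C)c2[nH]nc(NC(=O)c3ccccc3)c2CN1Cc1cccc(Cl)c1` gives 670 nM;
compound 2 `CC1(C)c2[nH]nc(NC(=O)c3ccccc3)c2CN1Cc1ccc(F)cc1` gives 1180 nM;
compound 3 `CC1(C)c2[nH]nc(NC(=O)c3ccccc3)c2CN1Cc1cc(F)cc(C(F)(F)F)c1` gives 1000 nM.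

Compound 2 carries the highest of the three numbers, yet its gaps to compound 3 and to compound 1 both fall within the usual scatter, so the three compounds cannot be placed in any order. Within the data shown here, the only step that touches compound 2 directly, a 1.8-fold higher number from compound 1 to compound 2 (0.25 log units; within the scatter), is itself within the scatter.

Compound 4 `CC1(C)c2[nH]nc(NC(=O)c3ccccc3)c2CN1Cc1cc(F)c(F)c(F)c1` differs from compound 2 by 3,4,5-trifluorophenyl in place of 4-fluorophenyl on a saturated chain carbon bound to an amine nitrogen in a ring. Among the measured compounds shown here, no measured step adds fluorine to a phenyl that already carries one, so nothing bears on this change directly; the nearest comparison is compound 3, which carries a different fluorinated phenyl at the same place and sits within scatter of compound 2. The expectation for compound 4 is therefore a step within the scatter, a 1.2-fold lower number from compound 2 to compound 4 (0.09 log units; within the scatter), with no direction claimed. Compound 4 is estimated at 950 nM, in the range 350 nM to 2600 nM.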

Compound 4, half-maximal inhibitory concentration: 6960 nM
The estimate for compound 4 lay 7.3-fold (0.86 log units) below the measured number, and the stated range ends below it.
By their numbers in this assay, from the lowest: compounds 1, 3 and 2 (each within the scatter of the next); then compound 4.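

In this assay, among these compounds, the place on a saturated chain carbon bound to an amine nitrogen in a ring now shows a real sensitivity: a 5.9-fold higher number from compound 2 to compound 4 (0.77 log units; beyond the scatter) is a step beyond the scatter, and a 10-fold higher number from compound 1 to compound 4 (1.02 log units; beyond the scatter) is also beyond it, whereas the earlier compounds differed only within the scatter. Fluorine on the phenyl does not by itself go with a higher number, since the fluorinated phenyl of compound 3 gives 1000 nM, so among these compounds the rise is confined to 3,4,5-trifluorophenyl. No measurement shown here accounts for this rise.

Going by these compounds, whether the higher number requires all three fluorines remains open, and a difluorophenyl at this place would bear on that. The compounds shown also leave open how an unsubstituted phenyl or a methoxyphenyl would read.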